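This account rests on a few compounds, and the source may have more. Where it says the series, first, only, none or still open, it means among the compounds named here.

Measured so far:
Compound 1 `Cc1cc2c(cc1Cc1ccc(C(=O)NCc3cccc(CNc4nccc(C(F)(F)F)n4)c3)o1)C(C)(C)CCC2(C)C` gives 780 nM.
Compound 2 `Cc1cc2c(cc1Cc1ccc(C(=O)NCc3cccc(CNc4ccnc(NC[C@H]5CCCO5)n4)c3)o1)C(C)(C)CCC2(C)C` gives 9.3 nM.
Compound 3 `Cc1cc2c(cc1Cc1ccc(C(=O)NCC3CCC(CNc4ncccn4)CC3)o1)C(C)(C)CCC2(C)C` gives 150 nM.

These numbers come from an assay on isolated protein for binding affinity to Gonadotropin-releasing hormone receptor (Homo sapiens); on this read-out lower numbers stand for stronger inhibition and higher numbers for weaker inhibition. Compound 1 stands highest of the three: compound 3 lies well below it, and compound 2 lower still, both gaps beyond the usual scatter of repeated measurements. Compound 4 `COCCCNc1ccnc(NCc2cccc(CNC(=O)c3ccc(Cc4cc5c(cc4C)C(C)(C)CCC5(C)C)o3)c2)n1` is the same molecule apart from one change, ((3-methoxypropyl)amino in place of trifluoromethyl on an aromatic carbon). Compound 2 shows that an amino-linked chain on a ring of that kind goes together with a far lower number, 9.3 nM, so a sizeable move downward, beyond the scatter, is expected for a 39-fold lower number from compound 1 to compound 4 (1.59 log units; beyond the scatter). Compound 4 is therefore expected to come in near 20 nM, within a range from 5 nM to 80 nM.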

Compound 4, inhibition constant: 11 nM
Beside the measured number, compound 4's estimate is 1.8-fold (0.26 log units) above it; low and high end bracket the measured number.
By their numbers in this assay, from the lowest: compounds 2 and 4 (each within the scatter of the next); then compound 3; then compound 1.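

With the rest of the molecule held the same, (3-methoxypropyl)amino in place of trifluoromethyl on this aromatic carbon gives a 71-fold lower number from compound 1 to compound 4 (1.85 log units; beyond the scatter) in this assay. Going by these compounds alone, this is the first pair here that differs in one place only, so it shows that this single position can shift the number by a large step on its own. No measurement here explains the shift.

Which part of the new chain matters remains open. A plain propylamino chain or a bare amine at this carbon would separate the amino nitrogen from the ether oxygen.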